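The source may report more compounds than this note shows. Statements on the series, on what has been measured and on what is new or still open speak of the compounds shown alone.

Measured compounds:
compound 1, `Cc1ccnc(N2C(=O)CS[C@@H]2c2cccc(C(=O)NCCCCn3cccn3)c2)c1`, gives 21.9 nM in a functional assay on HOS-TE85 cells (Homo sapiens) for inhibition, read by CCK-8 assay, with a stated time of 72 h; a lower number here means a stronger inhibitor, a higher number a weaker inhibitor.
compound 2, `COc1ccc(F)cc1N1C(=O)CSC1c1cccc(C(=O)NCCCCn2cccn2)c1`, gives 97.3 nM.
compound 3, `COc1ccc(F)cc1N1C(=O)CSC1c1cccc(C(=O)NCCCCc2ccccc2)c1`, gives 8.8 nM.

Compound 3 stands lowest of the three numbers in this assay; the nearest to it is compound 1, a step beyond the scatter, and the furthest is compound 2, further still. The unmeasured compound 4, `O=C(NCCCCc1ccccc1)c1cccc(C2SCC(=O)N2c2cccc(F)c2)c1`, differs from compound 3 in one place: hydrogen in place of methoxy on an aromatic carbon. For the measured compounds named here, the only single-place step measured so far, an 11-fold lower number from compound 2 to compound 3 (1.04 log units; beyond the scatter), concerns the group at the end of the four-carbon chain, not the ring on the core nitrogen, so it does not bear directly on this change. Compound 1 and compound 3 differ in more than one place, and their two values alone cannot be assigned to the methoxy. Going by the values given here, with no precedent for removing a methoxy here, no step beyond the scatter is expected in this assay, with a slight lean towards a higher number. Compound 4 is therefore estimated at 14 nM, within 5 nM to 40 nM, which means an expected step of a 1.6-fold higher number from compound 3 to compound 4 (0.20 log units; within the scatter).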

Compound 4, half-maximal inhibitory concentration in the HOS-TE85 assay: 32.4 nM
Compound 4: the middle estimate sits 2.3-fold (0.36 log units) below what was measured, within the range that was stated.
By their numbers in the HOS-TE85 assay, from the lowest: compound 3; then compounds 1 and 4 (each within the scatter of the next); then compound 2.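

Hydrogen in place of methoxy, ortho to a large group and para to a fluoro group, is the only single-place change shown on the ring at the core nitrogen, and in the HOS-TE85 assay it gives a 3.7-fold higher number from compound 3 to compound 4 (0.57 log units; beyond the scatter), so this methoxy does count towards the lower number of compound 3, with the 5-fluoro-2-methoxyphenyl ahead of the 3-fluorophenyl. In a physicochemical assay for solubility, read by turbidimetry, measured as kinetic solubility, at pH 7.4 (on this read-out higher numbers stand for higher solubility and lower numbers for lower solubility), compound 3 gives 10000 nM and compound 4 gives 10000 nM, and the same replacement shows no change at the digits printed from compound 3 to compound 4 (within the scatter). No measurement at hand accounts for the step in inhibition.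

The compounds shown leave open whether a hydroxyl, an ethoxy or a chloro group at this place would hold that lower number in the HOS-TE85 assay. They also leave open whether the same replacement would give a similar step with the 1H-pyrazol-1-yl group at the end of the chain.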